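This account rests on a few compounds, and the source may have more. Where it says the series, first, only, none or still open, it means among the compounds named here.

Compound 3 `COc1ccc2[nH]c(C(=O)N3CC(=O)N(Cc4ccccc4)[C@@H](CN4CC5(CCC5)C4)C3)cc2c1` gives 60700 nM in a physicochemical assay for solubility, read by spectrophotometry, in phosphate buffer, with a stated time of 2 h, at pH 7.4 (a lower number here means a less soluble compound, a higher number a more soluble compound), the second highest of the three numbers: compound 1 `COc1ccc2[nH]c(C(=O)N3CC(=O)N(Cc4ccccc4)[C@@H](CN4CCC(C)CC4)C3)cc2c1` gives 93100 nM, and compound 2 `COc1ccc2[nH]c(C(=O)N3CC(=O)N(Cc4ccccc4)[C@@H](COc4ccc(F)cc4)C3)cc2c1` gives 17500 nM. The move to compound 4 `COc1ccc2[nH]c(C(=O)N3CC(=O)N(Cc4ccccc4)[C@@H](CN4CCc5ccccc5C4)C3)cc2c1` is a group of 10 heavy atoms (9 carbon, 1 nitrogen; one six-membered non-aromatic ring with 1 hetero atom, one six-membered aromatic ring of carbon only) in place of a group of 7 heavy atoms (6 carbon, 1 nitrogen; one four-membered non-aromatic ring of carbon only, one four-membered non-aromatic ring with 1 hetero atom), on a saturated chain carbon bound to a saturated ring carbon. Going by the values given here, two measured steps bear on it. Swapping one nitrogen-containing saturated group for another left a 1.5-fold lower number from compound 1 to compound 3 (0.19 log units; within the scatter), while replacing the 4-fluorophenoxy group by the nitrogen-containing bicycle gave a 3.5-fold higher number from compound 2 to compound 3 (0.54 log units; beyond the scatter). Compound 4 keeps a nitrogen-containing saturated ring yet gains a six-membered aromatic ring, so the expected step is a 2.4-fold lower number from compound 3 to compound 4 (0.39 log units; beyond the scatter), a modest fall. Compound 4 is therefore estimated at 25000 nM, with a range of 10000 nM to 60000 nM.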

Compound 4, solubility: 9000 nM
Estimate against measurement, compound 4: 2.8-fold (0.44 log units) above, outside the stated range (below it).
By their numbers in this assay, from the lowest: compounds 4 and 2 (each within the scatter of the next); then compounds 3 and 1 (each within the scatter of the next).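

In this assay, the step from compound 3 is a 6.7-fold lower number from compound 3 to compound 4 (0.83 log units; beyond the scatter), and that from compound 1 is a 10-fold lower number from compound 1 to compound 4 (1.01 log units; beyond the scatter), so a nitrogen-containing ring at this place does not alone keep the number high. Against the 4-fluorophenoxy group, the change gives a 1.9-fold lower number from compound 2 to compound 4 (0.29 log units; within the scatter), leaving the two groups with a six-membered aromatic ring at the low end of the series. No measurement shown accounts for these steps. Going by these compounds, whether the aromatic ring or the larger group matters remains open; an open-chain benzylamine or a morpholin-4-yl group at this place would bear on that.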